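This account rests on a few compounds, and the source may have more. Where it says the series, first, only, none or still open, it means among the compounds named here.

Measured compounds:
compound 1 `N#CC1=C(N)N(c2ccc(S(N)(=O)=O)cc2)C2=C(C(=O)CCC2)C1c1ccc(O)cc1` — 100%
compound 2 `COc1ccccc1C1C(C#N)=C(N)N(c2ccc(S(N)(=O)=O)cc2)C2=C1C(=O)CCC2` — 0%
compound 3 `COc1ccc2ccccc2c1C1C(C#N)=C(N)N(c2ccc(S(N)(=O)=O)cc2)C2=C1C(=O)CCC2` — 70%

All three share one core and differ only in the group carried on a saturated ring carbon. In a functional assay on Ehrlich cells (Mus musculus) for antiproliferative activity, read by trypan blue exclusion, with a stated time of 2 h, tested at 50 ug/mL (a higher number here means a stronger effect of the compound at the concentration tested, a lower number a weaker effect), compound 2 gives 0%, the lowest of the three numbers; compound 3 stands nearest to it with 70%, and compound 1 stands furthest with 100%. Compound 4 `N#CC1=C(N)N(c2ccc(S(N)(=O)=O)cc2)C2=C(C(=O)CCC2)C1c1ccco1` has not yet been measured. Its change from compound 2 is furan-2-yl in place of 2-methoxyphenyl on a saturated ring carbon. For the measured compounds named here, no measured step tries furan-2-yl at this position, so the expectation rests on how freely the position tolerates an exchange. The step of a number 100 percentage points lower from compound 1 to compound 2 (beyond the scatter) and the step of a number 70 percentage points higher from compound 2 to compound 3 (beyond the scatter) show that the group here can move the read-out across its whole range, while the step of a number 30 percentage points lower from compound 1 to compound 3 (beyond the scatter) shows a smaller loss. Two of the three groups tried gave a clear effect and only 2-methoxyphenyl gave none, so a rise from compound 2 is expected, although its size is uncertain. For compound 4 the step of a number 50 percentage points higher from compound 2 to compound 4 (beyond the scatter) in this assay is what is expected. The estimate for compound 4 is 50%, within a range from 10% to 90%.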

Compound 4, a percentage reported as activity, at one concentration (the size of the read-out at that concentration, not a potency): 5%
Beside the measured number, compound 4's estimate is 45 percentage points above it; measured number outside the range, below it.
By their numbers in this assay, from the lowest: compounds 2 and 4 (each within the scatter of the next); then compound 3; then compound 1.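

In this assay, putting furan-2-yl in place of 2-methoxyphenyl on the saturated ring carbon gives a number 5 percentage points higher from compound 2 to compound 4 (within the scatter), so these two groups cannot be told apart here even though a five-membered aromatic ring with one hetero atom replaces a six-membered aromatic ring of carbon only. Against the other two groups, furan-2-yl gives a number 65 percentage points lower from compound 3 to compound 4 (beyond the scatter) and a number 95 percentage points lower from compound 1 to compound 4 (beyond the scatter), so the low read-out of compound 2 is no longer a single case, and among these four groups only 4-hydroxyphenyl and 2-methoxynaphthalen-1-yl give a clear effect. Nothing measured here offers a reason for these differences.

Going by these compounds, it remains open whether a plain phenyl, a 4-methoxyphenyl or a 2-hydroxyphenyl at this carbon would keep the effect of compound 1, and what a non-aromatic cyclohexyl ring or a butyl chain would do there. On these data alone, each read-out also comes from a single concentration, so how the four compounds compare in potency remains open as well.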